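A few compounds are considered here, and "the series" means these few. Any claim that something is new, unique, unknown or untested is made for them only; others in the source may bear on it.

Compound 1 `CCCCCCNC(=O)[C@H]1OC(n2cnc3c(N)ncnc32)[C@H](O)[C@@H]1O`: 19 nM
Compound 2 `Nc1ncnc2c1ncn2[C@@H]1O[C@H](C(=O)NC2CCCCC2)[C@@H](O)[C@H]1O`: 18 nM

Both numbers come from an assay on cell membranes for binding affinity to 2-oxoglutarate receptor 1 (Rattus norvegicus), read by radioligand binding; on this read-out higher numbers stand for weaker inhibition and lower numbers for stronger inhibition. Compound 1 has the higher of the two values, yet compound 2 lies within the usual scatter of it, so the two cannot be told apart on this read-out. Compound 3 `CC1CCCCC1NC(=O)[C@H]1OC(n2cnc3c(N)ncnc32)[C@H](O)[C@@H]1O` is not yet measured. It differs from compound 1 in one place: 2-methylcyclohexyl in place of hexyl on an amide-type nitrogen. Going by the values given here, no measured pair shows this change. With compound 2 already within the scatter of compound 1, the step is expected to be small and without clear direction, a 1.3-fold higher number from compound 1 to compound 3 (0.12 log units; within the scatter). Compound 3 is estimated at 25 nM, with a range from 8 nM to 80 nM.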

Compound 3, inhibition constant: 69.5 nM
Compound 3: middle estimate off by 2.8-fold (0.44 log units), on the low side; measured number inside the range.
By their numbers in this assay, from the lowest: compounds 2 and 1 (each within the scatter of the next); then compound 3.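

In this assay, the group on the amide-type nitrogen now makes a measurable difference: 2-methylcyclohexyl in place of hexyl weakens binding (a 3.7-fold higher number from compound 1 to compound 3 (0.56 log units; beyond the scatter)). Going by these compounds alone, compounds 1 and 2 could not be told apart, so this is the first step at this position to lie beyond the scatter. No measurement here explains the loss.

This single step replaces a chain with a ring carrying a methyl, so it cannot separate the effect of the ring from that of the methyl. As far as these compounds go, whether a longer chain or a phenyl group on the same nitrogen would keep the binding of compound 1 also remains open.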